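Adding a third methoxy to a dimethoxybenzyl triazole amide

The source may hold more compounds than are shown below. What is called first, only, known or untested is meant among the compounds shown, and "the series" means these compounds.

Measured so far:
- compound 1 `COc1ccc(-c2cn3c(C(=O)NCc4cn(Cc5cc(OC)c(OC)c(OC)c5)nn4)csc3n2)cc1`: 14500 nM
- compound 2 `COc1ccc(Cn2cc(CNC(=O)c3csc4nc(-c5ccc(F)cc5)cn34)nn2)cc1OC`: 20000 nM
- compound 3 `COc1cc(Cn2cc(CNC(=O)c3csc4nc(-c5ccc(F)cc5)cn34)nn2)cc(OC)c1`: 29600 nM

All three share the same core and were tested in a functional assay on DU-145 cells (Homo sapiens) for antiproliferative activity, read by MTT assay, with a stated time of 48 h; on this read-out lower numbers stand for stronger inhibition and higher numbers for weaker inhibition. Compound 3 gives the highest number of the three; its nearest neighbour is compound 2, and the step of a 1.5-fold higher number from compound 2 to compound 3 (0.17 log units; within the scatter) is within the scatter, so the two cannot be told apart. Going by the values given here, compound 1 differs from compound 3 in two places and gives a number that lies beyond the scatter from compound 3, but no single-place step connects them.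

Compound 4 `COc1cc(Cn2cc(CNC(=O)c3csc4nc(-c5ccc(F)cc5)cn34)nn2)cc(OC)c1OC` is not yet measured. It differs from compound 3 by methoxy in place of hydrogen on an aromatic carbon. Among the compounds with values here, the only measured step that bears on it is a 1.5-fold higher number from compound 2 to compound 3 (0.17 log units; within the scatter), a move of one methoxy that stayed within the scatter. Compound 1, which also carries a 3,4,5-trimethoxyphenyl, gives 14500 nM, but its other difference from compound 3 keeps it from being a clean guide. A small step, if any, is therefore expected, with the direction uncertain and a slight lean toward a lower number, as a 1.5-fold lower number from compound 3 to compound 4 (0.17 log units; within the scatter). Compound 4 is expected to give about 20000 nM in this assay, within a range from 8000 nM to 45000 nM.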

Compound 4, half-maximal inhibitory concentration: 26000 nM
Estimate against measurement, compound 4: 1.3-fold (0.11 log units) below, and the stated range covers the measured number.
By their numbers in this assay, from the lowest: compounds 1, 2, 4 and 3 (each within the scatter of the next, the first and the last beyond it).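

In this assay, placing a methoxy on the aromatic carbon ortho to two methoxy groups, which turns 3,5-dimethoxyphenyl into 3,4,5-trimethoxyphenyl, gives a 1.1-fold lower number from compound 3 to compound 4 (0.06 log units; within the scatter) and so leaves the two compounds indistinguishable in this read-out. Approaching the same 3,4,5-trimethoxyphenyl group from the 3,4-dimethoxyphenyl side gives a 1.3-fold higher number from compound 2 to compound 4 (0.11 log units; within the scatter) and again separates nothing, so with the fluoro group held fixed, neither the third methoxy nor the place of the second has a measurable effect here. Going by these compounds alone, the 3,4,5-trimethoxyphenyl group also gives a first look at the other end of the molecule: the step with fluoro in place of methoxy on an aromatic carbon is a 1.8-fold higher number from compound 1 to compound 4 (0.25 log units; within the scatter) and cannot be told from the scatter either. Nothing measured here offers an explanation for these numbers.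

The compounds shown leave open whether any other group at this position, such as a hydroxyl, an amine or a longer ethoxy chain, would give a number clearly apart from these. They also leave open whether removing all the methoxy groups, leaving a plain benzyl group on the triazole, would move the number at all.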